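A few compounds are considered here, and "the series" means these few. Any claim that something is new, unique, unknown or untested is made for them only; others in the source may bear on it.

In an in vitro functional assay on B300-19 cells for antagonist activity at C-C chemokine receptor type 4 (Homo sapiens), read by GTPgammaS binding, tested at 1 uM (on this read-out lower numbers stand for less inhibition and higher numbers for more inhibition at the one concentration tested (going by the name of the read-out)), the measured compounds are:
compound 1 `COc1cc2nc(NCc3ccccc3)nc(NC3CCCCCC3)c2cc1OC`: 13%
compound 2 `COc1cc2nc(N3CCC(N4CCCC4)CC3)nc(N(C)C)c2cc1OC`: < 0%
compound 3 `COc1cc2nc(N3CCC(Cc4ccccc4)CC3)nc(NC3CCCCCC3)c2cc1OC`: 1%

Compound 1 holds the highest of the two numbers; the nearest, compound 3, lies lower by more than the usual scatter. Compound 2 reaches (the limit of < 0% in this assay, at which 1 of the 3 values shown sits), which is a limit of the assay and not a number.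

Compound 4 `COc1cc2nc(NCc3cccs3)nc(NC3CCCCCC3)c2cc1OC` differs from compound 1 in one place: thiophen-2-yl in place of phenyl on a saturated chain carbon bound to a nitrogen on an aromatic ring. Going by the values given here, no step between two measured compounds is available, so the expectation rests on compound 1 alone. The exchange of one small aromatic ring for another is expected to shift the inhibition only a little, within the scatter, as a number 3 percentage points lower from compound 1 to compound 4 (within the scatter). Compound 4 is therefore estimated at 10%, with a range from -2% to 24%.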

Compound 4, a percentage reported as inhibition, at one concentration (the size of the read-out at that concentration, not a potency): 0%
For compound 4 the middle estimate is 10 percentage points above the measured one; the range from low to high includes it.
By their numbers in this assay, from the lowest: compounds 4 and 3 (each within the scatter of the next); then compound 1.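

In this assay, going by these compounds alone, thiophen-2-yl in place of phenyl on a saturated chain carbon bound to a nitrogen on an aromatic ring gives a number 13 percentage points lower from compound 1 to compound 4 (beyond the scatter), the first step that can be read at this place. The read-out at this place therefore responds to the exchange of one small aromatic ring for another. Nothing measured here bears on the reason for this step. The compounds shown leave open how an amine or a carboxylic acid on the phenyl would read in this assay. They also leave open a longer chain in place of the benzyl.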